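The source may hold more compounds than are shown below. What is called first, only, known or untested is meant among the compounds shown, and "the series" means these compounds.

Measured so far in a functional assay on MCF7 cells (Homo sapiens) for inhibition, read by MTT assay, with a stated time of 72 h; a lower number here means a stronger inhibitor, a higher number a weaker inhibitor:
compound 1 `Cc1cc(Nc2cc(-c3ccccc3)[nH]n2)n2nc(SCc3cccc(Br)c3)nc2n1` gives 5140 nM
compound 2 `CCCCCc1c(C)nc2nc(SCc3ccc(Cl)cc3)nn2c1Nc1cc(-c2ccccc2)[nH]n1` gives 6390 nM
compound 3 `COc1ccc(Cn2ccc(Nc3cc(C)nc4nc(SCc5ccc(Br)cc5)nn34)n2)cc1` gives 14600 nM

Compound 1 holds the lowest of the three numbers in this assay. Compound 2 sits within the usual scatter of compound 1, so no order between the two is claimed. Compound 3 lies beyond the scatter and is the weaker inhibitor of that pair.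

Compound 4 `Cc1cc(Nc2cc(-c3ccccc3)[nH]n2)n2nc(SCC(=O)c3ccccc3)nc2n1` is not yet measured in this assay. It differs from compound 1 in a single place: benzoyl in place of 3-bromophenyl on a saturated chain carbon bound to a sulfur. For the measured compounds named here, no measured pair carries this change, so its effect is unknown; the three numbers at hand all fall in a narrow band. The step from compound 1 is expected to be a 1.2-fold higher number from compound 1 to compound 4 (0.07 log units; within the scatter), none beyond the scatter in either direction. Compound 4 is therefore estimated at 6000 nM in this assay, with a range of 2500 nM to 15000 nM.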

Compound 4, half-maximal inhibitory concentration: 5240 nM
For compound 4 the middle estimate is 1.1-fold (0.06 log units) above the measured one; measured number inside the range.
By their numbers in this assay, from the lowest: compounds 1, 4 and 2 (each within the scatter of the next); then compound 3.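

In this assay benzoyl in place of 3-bromophenyl on a saturated chain carbon bound to a sulfur gives a 1.0-fold higher number from compound 1 to compound 4 (0.01 log units; within the scatter) and so no readable change at this position. For the compounds shown here, the earlier compounds all carry a halogen-bearing benzyl group on the sulfur, so only this pair shows that the bromine can go and a carbonyl can enter with the number staying within the scatter. No measurement at hand speaks to why.

From the compounds shown here alone, whether an amine, a carboxylic acid or a longer chain at this place would move the number stays open.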